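The source may report more compounds than this note shows. Statements on the series, on what has been measured and on what is new or still open speak of the compounds shown alone.

Measured so far:
compound 1, `COc1ccc(NS(=O)(=O)c2cc(Cl)cc(Cl)c2)cc1N1CCN(C)CC1`, giving 2 nM
compound 2, `COc1ccc(NS(=O)(=O)c2c(F)c(Br)cc(F)c2Br)cc1N1CCN(C)CC1`, giving 3.16 nM

Both compounds were tested in an assay on HeLa cells for binding affinity to 5-hydroxytryptamine receptor 6 (Homo sapiens); a lower number here means a stronger inhibitor, a higher number a weaker inhibitor. Compound 1 gives 2 nM, the lowest of the two numbers, and compound 2 gives 3.16 nM; the gap between these two values lies within the usual scatter of the assay, so the two compounds cannot be told apart on this evidence. The two compounds share a core and differ only in the aryl group carried on the sulfonyl sulfur, and neither number favours one halogen pattern over the other.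

Compound 3, `COc1ccc(NS(=O)(=O)c2ccccc2)cc1N1CCN(C)CC1`, has not yet been measured in this assay. Relative to compound 1 the change is phenyl in place of 3,5-dichlorophenyl on a sulfonyl sulfur. Within the data shown here, no measured pair in this set isolates the loss of ring substituents from the sulfonyl aryl group, so the step can only be estimated. Compound 3 is expected to be somewhat weaker than compound 1, with an estimated step of a 5.0-fold higher number from compound 1 to compound 3 (0.70 log units; beyond the scatter), beyond the scatter but modest. The estimate for compound 3 is 10 nM, within a range from 3 nM to 40 nM.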

Compound 3, inhibition constant: 10 nM
Compound 3: middle estimate and measured number agree at the digits printed; low and high end bracket the measured number.
By their numbers in this assay, from the lowest: compounds 1 and 2 (each within the scatter of the next); then compound 3.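

In this assay, among these compounds, the step of a 5.0-fold higher number from compound 1 to compound 3 (0.70 log units; beyond the scatter) is the first reading in this set of a single change at this position, phenyl in place of 3,5-dichlorophenyl on a sulfonyl sulfur. Among the compounds shown here, until now the position had offered only two heavily halogenated aryl groups that could not be told apart, whereas this pair shows that removing the chlorine atoms has a real though modest cost. It also shows that the chlorine atoms are not needed for binding in the low nanomolar range, since compound 3 with its bare phenyl still gives 10 nM in this assay. No measurement here bears on why the number moves, so the step stands without an explanation.

The compounds shown leave open whether the chlorine atoms act together or whether one alone would recover the number of compound 1, and how the fluorine and bromine atoms of compound 2 would each fare on their own. They also leave open whether a non-halogen group on the phenyl, such as a methyl, a methoxy, a nitrile or an amine, could take the place of chlorine.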